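Ester replaces ether on the methylene arm

A few compounds are considered here, and "the series" means these few. Any claim that something is new, unique, unknown or untested is made for them only; others in the source may bear on it.

Of the compounds shown here, three sharing one core have been measured in a functional assay on the whole organism with Rattus norvegicus as the target, with a stated time of 4 h, at a dose of 40 mg/kg by the intraperitoneal route; on this read-out lower numbers stand for less inhibition and higher numbers for more inhibition at the one dose given (going by the name of the read-out). Compound 1 `Cc1nc2c(OCc3ccccc3)cccn2c1C(N)=O` carries a carbamoyl on the aromatic carbon and gives 42%. Compound 2 `[C-]#[N+]Cc1c(C)nc2c(OCc3ccccc3)cccn12` gives 96%, and compound 3 `CCOCc1c(C)nc2c(OCc3ccccc3)cccn12` gives 84%. Compound 3 thus stands second of the three: the step of a number 12 percentage points lower from compound 2 to compound 3 (beyond the scatter) is modest, while the step of a number 42 percentage points higher from compound 1 to compound 3 (beyond the scatter) is large, both beyond the scatter.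

Compound 4 `COC(=O)Cc1c(C)nc2c(OCc3ccccc3)cccn12` differs from compound 3 at the saturated chain carbon bound to the aromatic carbon: methoxycarbonyl in place of ethoxy on a saturated chain carbon bound to an aromatic carbon. The step of a number 12 percentage points lower from compound 2 to compound 3 (beyond the scatter) shows that a swap at this carbon moves the read-out only modestly, whereas the step of a number 42 percentage points higher from compound 1 to compound 3 (beyond the scatter) shows that a carbonyl-bearing group on the aromatic carbon, as in compound 1, gives a far lower number. Because compound 1 with its carbonyl gives 42%, a downward step is expected for compound 4, estimated as a number 22 percentage points lower from compound 3 to compound 4 (beyond the scatter). Compound 4 is therefore expected to give about 62%, within a range from 35% to 85%.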

Compound 4, a percentage reported as inhibition, in the whole organism at one dose (the size of the read-out at that dose, not a potency): 23%
The estimate for compound 4 lay 39 percentage points above the measured number; the measured number lies below the stated range.
By their numbers in this assay, from the lowest: compound 4; then compound 1; then compound 3; then compound 2.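

At the saturated chain carbon bound to an aromatic carbon, the earlier swap moved the number only modestly, yet methoxycarbonyl in place of ethoxy in this assay brings a number 61 percentage points lower from compound 3 to compound 4 (beyond the scatter) and shows that this carbon does not accept every group equally. Starting from the group of compound 2, the same carbon shows a number 73 percentage points lower from compound 2 to compound 4 (beyond the scatter) as the largest step in the set. The ester arm also falls short of the carbamoyl compound, with a number 19 percentage points lower from compound 1 to compound 4 (beyond the scatter) as the step, so compound 1 and compound 4, the two that carry a carbonyl, hold the two lowest numbers.

Going by these compounds, whether a carboxylic acid or an amide on this arm would stay as low, or a longer ether chain as high, remains open. Nothing available here explains why the ester arm gives so low a number.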